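Swapping Ethoxy for Methanesulfonamido: Expected Cytotoxicity

A few compounds are considered here, and "the series" means these few. Any claim that something is new, unique, unknown or untested is made for them only; others in the source may bear on it.

Measured compounds:
compound 1 `COc1ccc(-c2csc(NC(=O)c3ccc([N+](=O)[O-])o3)n2)cc1` gives 63000 nM
compound 2 `CCOc1cccc(-c2csc(NC(=O)c3ccc([N+](=O)[O-])o3)n2)c1` gives > 90000 nM
compound 3 `Cc1cc(C)c(-c2csc(NC(=O)c3ccc([N+](=O)[O-])o3)n2)c(C)c1` gives 30400 nM

All three were tested in an ADME assay on Vero cells (Chlorocebus sabaeus) for cytotoxicity, read by MTT assay, with a stated time of 72 h; a lower number here means a stronger inhibitor, a higher number a weaker inhibitor. Compound 1 and compound 3 return numbers. For compound 2 the assay reports only a limit, > 90000 nM, not a number. Compound 2 therefore stands at the limit of > 90000 nM in this assay, at which 1 of the 3 values shown sits, the weakest end of what this assay can report.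

Compound 4 `CS(=O)(=O)Nc1cccc(-c2csc(NC(=O)c3ccc([N+](=O)[O-])o3)n2)c1` differs from compound 2 in one place: methanesulfonamido in place of ethoxy on an aromatic carbon. For the measured compounds named here, no measured pair in this set differs in just one place, so this step has no direct precedent here. Compound 4 is expected to remain weak in this assay, with an estimated step of an at least 1.1-fold lower number from compound 2 to compound 4 (0.05 log units; that floor lies within the scatter) that stays within the usual scatter. The estimate for compound 4 is 80000 nM, between 35000 nM and 200000 nM.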

Compound 4, half-maximal inhibitory concentration: < 2820 nM
Compound 4 ended at the assay's limit; the forecaster's own chance of this, stated with the estimate: 50%; middle value at least 28-fold (1.45 log units) from the limit.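

On this position of the aromatic ring, the choice of group matters greatly in this assay: methanesulfonamido in place of ethoxy gives an at least 31-fold lower number from compound 2 to compound 4 (1.50 log units; beyond the scatter). Compound 1 and compound 3 differ from compound 2 in more than one place, so neither could reveal this. Compound 4 returns only a limit, not a number: the limit of < 2820 nM in this assay, at which 1 of the 4 values shown sits.

As far as these compounds go, the true size of the step therefore stays open, since compound 2 also returns only a limit. Also open, from the compounds shown here alone, is whether an amine or a carboxylic acid in the same place would lower the number as much as methanesulfonamido does.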